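Pyridin-4-yl to pyridin-3-yl: a clearance estimate

The source may report more compounds than this note shows. Statements on the series, on what has been measured and on what is new or still open speak of the compounds shown alone.

Compound 1 `O=C(N[C@@H]1CCCC[C@H]1O)c1cnc(OCC(F)(F)F)c(-c2ccc(Cl)cc2)c1`: 0.023 mL/min/kg
Compound 2 `O=C(N[C@@H]1CCCC[C@H]1O)c1cnc(OCc2ccncc2)c(-c2ccc(Cl)cc2)c1`: 0.118 mL/min/kg

In an ADME assay (liver) for pharmacokinetics, with Liver microsome (Rattus norvegicus) as the target, read by LC-MS, using microsomes, tested at 2 uM (a higher number here means faster removal of the compound, a lower number slower removal), compound 2 holds the higher of the two numbers, at 0.118 mL/min/kg. Compound 3 `O=C(N[C@@H]1CCCC[C@H]1O)c1cnc(OCc2cccnc2)c(-c2ccc(Cl)cc2)c1` differs from it thus: pyridin-3-yl in place of pyridin-4-yl on a saturated chain carbon bound to an oxygen on an aromatic ring. Pyridin-3-yl stands in place of pyridin-4-yl on a saturated chain carbon bound to an oxygen on an aromatic ring. For the measured compounds named here, the only measured step at this place, a 5.1-fold higher number from compound 1 to compound 2 (0.71 log units; beyond the scatter), replaced trifluoromethyl with pyridin-4-yl, and no measured step compares two pyridinyl groups. No step beyond the scatter is therefore expected in this assay. The expected step is a 1.1-fold lower number from compound 2 to compound 3 (0.03 log units; within the scatter). For compound 3 the estimate is 0.11 mL/min/kg, with an expected range of 0.05 mL/min/kg to 0.25 mL/min/kg.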

Compound 3, clearance: 0.374 mL/min/kg
Compound 3: middle estimate off by 3.4-fold (0.53 log units), on the low side, outside the stated range (above it).
By their numbers in this assay, from the lowest: compound 1; then compound 2; then compound 3.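

In this assay, pyridin-3-yl and pyridin-4-yl carry the same counted atoms on the saturated chain carbon, yet the exchange is not neutral at this place (a 3.2-fold higher number from compound 2 to compound 3 (0.50 log units; beyond the scatter)). Measured against trifluoromethyl, pyridin-3-yl gives the larger step (a 16-fold higher number from compound 1 to compound 3 (1.21 log units; beyond the scatter)), so the attachment point of the pyridine ring matters here as well as its presence. Nothing available explains this difference between the two pyridinyl groups. On these data alone, it remains open where pyridin-2-yl or a plain phenyl ring would fall at this place, and whether a morpholine would follow either pyridinyl group.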